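Phenylsulfonyl for Carboxybutyl: What Compound 4 Might Show

The source may hold more compounds than are shown below. What is called first, only, known or untested is meant among the compounds shown, and "the series" means these compounds.

Measured compounds:
compound 1 `CCC(CC)(c1ccc(OS(=O)(=O)c2ccc(C)cc2)c(C)c1)c1ccc(OCC(O)C(C)(C)C)c(OCC(O)C(C)(C)C)c1`: 43%
compound 2 `CCC(CC)(c1ccc(OCCCO)c(C)c1)c1ccc(OCC(O)C(C)(C)C)c(OCC(O)C(C)(C)C)c1`: 76%
compound 3 `CCC(CC)(c1ccc(OCCCCC(=O)O)c(C)c1)c1ccc(OCC(O)C(C)(C)C)c(OCC(O)C(C)(C)C)c1`: "not active" (no number reported)

In an assay on cells for binding affinity to vitamin D3 receptor (Homo sapiens), read by fluorescence, tested at 1 uM (on this read-out lower numbers stand for less inhibition and higher numbers for more inhibition at the one concentration tested (going by the name of the read-out)), compound 1 gives 43% and compound 2 gives 76%. Compound 3 is reported only as "not active" (no number reported), so no single number marks where it stands. Going by the values given here, the one measured step, a number 33 percentage points higher from compound 1 to compound 2 (beyond the scatter), is large. Compound 4 `CCC(CC)(c1ccc(OS(=O)(=O)c2ccccc2)c(C)c1)c1ccc(OCC(O)C(C)(C)C)c(OCC(O)C(C)(C)C)c1` differs from compound 3 by phenylsulfonyl in place of 4-carboxybutyl on an oxygen on an aromatic ring. That step is not one of the measured ones, but compound 4 comes close in structure to compound 1, whose value in this assay is 43%. Compound 4 is therefore expected to lie near that value, estimated at 40% with a range from 20% to 60%.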

Compound 4, a percentage reported as inhibition, at one concentration (the size of the read-out at that concentration, not a potency): "not active" (no number reported)
No number was reported for compound 4; there is nothing to compare the estimate with.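

Compound 3 and compound 4 are both reported only as "not active", without a number, so no step can be read between them. The compounds shown leave open whether 4-carboxybutyl and phenylsulfonyl differ at all in this assay. Nothing at hand bears on this result.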